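The source may report more compounds than this note shows. Statements on the series, on what has been measured and on what is new or still open speak of the compounds shown alone.

Going by the values given here, in a functional assay on HeLa cells (Homo sapiens) for cytotoxicity, read by MTT assay, with a stated time of 24 h (a lower number here means a stronger inhibitor, a higher number a weaker inhibitor), compound 1 `CN1C/C(=C\c2cccc([N+](=O)[O-])c2)C(=O)/C(=C/c2ccccc2F)C1` gives 2340 nM, the lower of the two numbers so far, and the gap to compound 2 `COc1cc(/C=C2\CN(C)C/C(=C\c3ccc(Br)cc3)C2=O)cc(OC)c1OC` at 11900 nM lies beyond the scatter. Compound 3 `CN1C/C(=C\c2ccc(Br)cc2)C(=O)/C(=C/c2cccc([N+](=O)[O-])c2)C1` remains unmeasured. It differs from compound 1 by 4-bromophenyl in place of 2-fluorophenyl on a double-bonded chain carbon bound to a double-bonded ring carbon. Among the compounds with values here, no measured pair isolates this change, but compound 2, which also carries 4-bromophenyl, gives 11900 nM, so a small rise in this assay is expected, near the edge of the scatter. The expected step is a 1.9-fold higher number from compound 1 to compound 3 (0.28 log units; within the scatter). Compound 3 is estimated at 4500 nM, with an expected range from 1600 nM to 12500 nM.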

Compound 3, half-maximal inhibitory concentration: 11900 nM
Beside the measured number, compound 3's estimate is 2.6-fold (0.42 log units) below it; the measured number falls inside the stated range.
By their numbers in this assay, from the lowest: compound 1; then compounds 2 and 3 (each within the scatter of the next).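

In this assay, going by these compounds alone, 4-bromophenyl in place of 2-fluorophenyl on a double-bonded chain carbon bound to a double-bonded ring carbon gives a 5.1-fold higher number from compound 1 to compound 3 (0.71 log units; beyond the scatter) as the first isolated reading of this change. It shows that, on the core of compound 1, the number responds to the group at this position. Nothing available accounts for the step.

This single pair cannot separate the effect of swapping fluorine for bromine from that of moving the substituent on the phenyl ring. Going by these compounds, how an unsubstituted phenyl or an aminophenyl would read here remains open.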